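Amine swap on the bromo-bearing core of compound 3

A few compounds are considered here, and "the series" means these few. Any claim that something is new, unique, unknown or untested is made for them only; others in the source may bear on it.

Three benzimidazole sulfoxides carrying an amino-substituted pyridine have numbers in a functional assay on the whole organism (stomach) for inhibition, with Canis familiaris (Canis lupus familiaris) as the target; on this read-out lower numbers stand for an effect already at smaller amounts and higher numbers for an effect only at larger amounts of compound. Compound 1 `COc1ccc2[nH]c([S+]([O-])Cc3nccc(N4CCCCC4)c3Cl)nc2c1` gives 1.16 umol/kg. Compound 2 `COc1ccc2[nH]c([S+]([O-])Cc3nccc(N(C)C)c3Cl)nc2c1` gives 0.26 umol/kg. Compound 3 `COc1ccc2[nH]c([S+]([O-])Cc3cc(N4CCCCC4)c(Br)cn3)nc2c1` gives 2.94 umol/kg, the highest number of the three. The difference between the core of compound 1 and the core of compound 3 is not broken down here.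

Within the first pair the change is dimethylamino in place of piperidin-1-yl on an aromatic carbon; it made a step of a 4.5-fold lower number from compound 1 to compound 2 (0.65 log units; beyond the scatter). Compound 4 `COc1ccc2[nH]c([S+]([O-])Cc3cc(N(C)C)c(Br)cn3)nc2c1` is not yet measured; it differs from compound 3 by dimethylamino in place of piperidin-1-yl on an aromatic carbon. This is the same kind of change, though around the place the surroundings differ: in the first pair the group is ortho to a chloro group, in the second it is ortho to a bromo group.

On the core of compound 3 a step of about a 4.2-fold lower number from compound 3 to compound 4 (0.62 log units; beyond the scatter) is expected in this assay, resting on compound 1 and compound 2 and their step of a 4.5-fold lower number from compound 1 to compound 2 (0.65 log units; beyond the scatter). Compound 4 is therefore estimated at 0.7 umol/kg, with a likely range from 0.3 umol/kg to 1.6 umol/kg.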

Compound 4, dose for half-maximal effect in the Canis familiaris assay: 0.91 umol/kg
The estimate for compound 4 lay 1.3-fold (0.11 log units) below the measured number; the measured number falls inside the stated range.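

In the Canis familiaris assay compound 3 gives 2.94 umol/kg and compound 4 gives 0.91 umol/kg. In the Canis familiaris assay, dimethylamino in place of piperidin-1-yl on the core of compound 3 gives a 3.2-fold lower number from compound 3 to compound 4 (0.51 log units; beyond the scatter). The change carries over between the two cores shown with no difference in step size beyond the scatter: the same change on two cores in the Canis familiaris assay, a 4.5-fold lower number (0.65 log units; beyond the scatter) from compound 1 to compound 2 and a 3.2-fold lower number (0.51 log units; beyond the scatter) from compound 3 to compound 4, 1.4-fold (0.14 log units) apart, within the scatter of two such steps. Within the data shown here, this rests on only two pairs and does not show what underlies the step. In a physicochemical assay for acid dissociation, compound 3 gives 5.4 and compound 4 gives 5.8. In the physicochemical assay the same change gives a number 0.40 log units higher from compound 3 to compound 4 (beyond the scatter), but with this read-out available for one pair only, no link between the two steps can be drawn.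

Open, on these data alone, is whether a morpholin-4-yl or pyrrolidin-1-yl group in the same place would follow the same trend on both cores. Also open, as far as these compounds go, is whether the step holds on a core with a methoxy group in place of the bromo group, and whether the numbers in the Canis familiaris assay track those in the physicochemical assay across more than one pair.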